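The compounds below may be only part of what the source reports. "The series", "measured", "known", "first", "only" and "open" are said of these compounds alone.

Measured in a functional assay on MCF7 cells (Homo sapiens) for cytotoxicity, read by sulforhodamine B assay, with a stated time of 72 h; on this read-out higher numbers stand for weaker inhibition and lower numbers for stronger inhibition:
- compound 1 `CC(=O)O[C@@]1([C@@H]2/C(C)=C(/OC(=O)OC(C)(C)C)C(=O)C3=C(C)[C@@H](OC(=O)[C@H](O)[C@H](CC(C)C)NC(=O)OC(C)(C)C)C[C@@](O)([C@H]2OC(=O)c2ccccc2)C3(C)C)CO[C@@H]1CCOC(=O)OC(C)(C)C`: 736 nM
- compound 2 `CC(=O)O[C@@]1([C@@H]2/C(C)=C(/OC(=O)OCc3ccccc3)C(=O)C3=C(C)[C@@H](OC(=O)[C@H](O)[C@H](CC(C)C)NC(=O)OC(C)(C)C)C[C@@](O)([C@H]2OC(=O)c2ccccc2)C3(C)C)CO[C@@H]1CCO`: 1210 nM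

The values of compound 1 and compound 2 lie within the scatter of each other, so compound 2 cannot be ranked on the numbers shown. Compound 3 `CC(=O)O/C1=C(\C)[C@@H]([C@]2(OC(C)=O)CO[C@@H]2CCO)[C@H](OC(=O)c2ccccc2)[C@]2(O)C[C@H](OC(=O)[C@H](O)[C@H](CC(C)C)NC(=O)OC(C)(C)C)C(C)=C(C1=O)C2(C)C` carries methyl in place of benzyloxy on a carbonyl carbon, so benzyloxycarbonyl gives way to acetyl. Among the compounds with values here, no measured pair shows this exchange, and the expectation is therefore loose. In this assay, the expected 2.4-fold lower number from compound 2 to compound 3 (0.38 log units; beyond the scatter) is modest, towards stronger inhibition, and may not clear the scatter. For compound 3 the estimated value is 500 nM, with an expected range of 120 nM to 2000 nM.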

Compound 3, half-maximal inhibitory concentration: 1000 nM
For compound 3 the middle estimate is 2.0-fold (0.30 log units) below the measured one, within the range that was stated.
By their numbers in this assay, from the lowest: compounds 1, 3 and 2 (each within the scatter of the next).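

In this assay, replacing benzyloxy with methyl on a carbonyl carbon gives a 1.2-fold lower number from compound 2 to compound 3 (0.08 log units; within the scatter) and so stays within the scatter. At this place, benzyloxycarbonyl and acetyl therefore cannot be told apart, and losing the six-membered aromatic ring of benzyloxy brings no readable change in this pair. Nothing available here accounts for this result.

As far as these compounds go, whether an amine, a carboxylic acid or a longer chain on the same carbonyl carbon would also stay within the scatter remains open. So does whether this pair's result would hold on a different remainder of the molecule.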